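Swapping nitro for bromo at a limit value

The source may hold more compounds than are shown below. What is called first, only, known or untested is meant among the compounds shown, and "the series" means these compounds.

Compound 1 `O=C(/C(=C\c1ccc(Br)cc1)SCc1ccc(Cl)cc1)c1ccc(Br)cc1` gives 1000 nM
Compound 2 `CN(C)c1ccc(/C=C(/SCc2ccc(Cl)cc2)C(=O)c2ccc(C(=O)O)cc2)cc1` gives 1000 nM
Compound 3 `CN(C)c1ccc(/C=C(/SCc2ccc(Cl)cc2)C(=O)c2ccc([N+](=O)[O-])cc2)cc1` gives > 100000 nM as a limit

All three were tested in a functional assay on DU-145 cells (Homo sapiens) for inhibition, read by trypan blue exclusion, with a stated time of 96 h (on this read-out higher numbers stand for weaker inhibition of growth and lower numbers for stronger inhibition of growth), and nothing else is at hand. Compound 3 stands at the limit of > 100000 nM in this assay, at which 1 of the 3 values shown sits, and so has a limit, not a number.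

Compound 4 `CN(C)c1ccc(/C=C(/SCc2ccc(Cl)cc2)C(=O)c2ccc(Br)cc2)cc1` changes one group of compound 3, from 4-nitrophenyl to 4-bromophenyl: bromo in place of nitro on an aromatic carbon and nothing else.

Going by the values given here, the one measured step at this group is large: an at least 100-fold higher number from compound 2 to compound 3 (2.00 log units; beyond the scatter) with nitro in place of carboxy on an aromatic carbon. Compound 1 also carries 4-bromophenyl and gives 1000 nM on a different core. A large move to lower numbers is therefore expected in this assay and the estimate means an at least 33-fold lower number from compound 3 to compound 4 (1.52 log units; beyond the scatter) as the expected step. Compound 4 is estimated at 3000 nM (expected range 400 nM to 50000 nM).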

Compound 4, concentration for 50% growth inhibition: 10000 nM
Estimate against measurement, compound 4: 3.3-fold (0.52 log units) below; the measured number falls inside the stated range.
By their numbers in this assay, from the lowest: compounds 1 and 2 (each within the scatter of the next); then compound 4. At a limit, above all of these: compound 3.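

Bromo at this position gives a measurable number in this assay, with an at least 10-fold lower number from compound 3 to compound 4 (1.00 log units; beyond the scatter), yet it does not match carboxy, with a 10-fold higher number from compound 2 to compound 4 (1.00 log units; beyond the scatter). Compound 3 has only a limit, so the first of these steps has no exact size: the limit of > 100000 nM in this assay, at which 1 of the 4 values shown sits. The group on the other aromatic ring also counts, with a 10-fold higher number from compound 1 to compound 4 (1.00 log units; beyond the scatter) for dimethylamino in place of bromo.

On these data alone, how an amine or a methoxy group would compare at this position remains open. So does whether carboxy and nitro would keep their order with bromo on the other ring.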